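A Methoxy Added to the Anilide Ring of Compound 3

A few compounds are considered here, and "the series" means these few. Any claim that something is new, unique, unknown or untested is made for them only; others in the source may bear on it.

Measured compounds:
compound 1, `CC(C)(C)c1cc(NC(=O)Nc2ccc(F)cc2)n(-c2ccccc2)n1`: 7.4 degrees C
compound 2, `Cc1cc(C)cc(NC(=O)Nc2cc(C(C)(C)C)nn2-c2ccccc2)c1`: 2.4 degrees C
compound 3, `CC(C)(C)c1cc(NC(=O)Nc2ccccc2)n(-c2ccccc2)n1`: 7.7 degrees C

In an assay on isolated protein for inhibition of STE20-like serine/threonine-protein kinase (Homo sapiens), read by thermal shift assay, tested at 10 uM (a higher number here means that the compound stabilises the target more against heat, a lower number that the compound stabilises the target less), compound 3 sits at the top of the three numbers together with compound 1, the gap being a number 0.30 degrees C higher from compound 1 to compound 3 (within the scatter); compound 2 lies well below, by a number 5.3 degrees C higher from compound 2 to compound 3 (beyond the scatter). Compound 4, `COc1cccc(NC(=O)Nc2cc(C(C)(C)C)nn2-c2ccccc2)c1`, differs from compound 3 by methoxy in place of hydrogen on an aromatic carbon. Going by the values given here, two measured steps bear on the same ring: a fluoro changed little, a number 0.30 degrees C higher from compound 1 to compound 3 (within the scatter), while two methyl groups cost much, a number 5.0 degrees C lower from compound 1 to compound 2 (beyond the scatter). A single methoxy is expected to fall between these outcomes, with a moderate loss in this assay. Compound 4 is therefore estimated at 5.5 degrees C, within 3 degrees C to 8 degrees C. The step this estimate implies is a number 2.2 degrees C lower from compound 3 to compound 4 (beyond the scatter).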

Compound 4, shift of the target's melting temperature: 3.6 degrees C
Compound 4: middle estimate off by 1.9 degrees C, on the high side; the range from low to high includes it.
By their numbers in this assay, from the lowest: compound 2; then compound 4; then compounds 1 and 3 (each within the scatter of the next).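

In this assay, one methoxy on this ring, meta to a large group, is enough for a large loss, a number 4.1 degrees C lower from compound 3 to compound 4 (beyond the scatter), so the loss seen on this ring does not depend on having two added groups. The 3-methoxyphenyl group still gives a modest gain over 3,5-dimethylphenyl, a number 1.2 degrees C higher from compound 2 to compound 4 (beyond the scatter), yet it stays clearly behind 4-fluorophenyl, a number 3.8 degrees C lower from compound 1 to compound 4 (beyond the scatter). Nothing available explains why this change lowers the thermal shift. The compounds shown leave open whether an amine or a hydroxyl at this same place would lose as much. They also leave open whether a methoxy in the place of the fluoro of compound 1 would do so.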